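Phenyl for 2-hydroxyethyl on the amine nitrogen

The compounds below may be only part of what the source reports. "The series", "measured", "known", "first", "only" and "open" are said of these compounds alone.

Measured so far in a functional assay on MCF7 cells (Homo sapiens) for antiproliferative activity; on this read-out lower numbers stand for stronger inhibition and higher numbers for weaker inhibition:
- Compound 1 `CC(C)=CCc1cc(C(=O)Nc2cc3ccc(OCC4CCCN(C)C4)c(C)c3oc2=O)ccc1O` gives 2640 nM
- Compound 2 `CC(C)=CCc1cc(C(=O)Nc2cc3ccc(OCCCNCCO)c(C)c3oc2=O)ccc1O` gives 1560 nM

Going by the values given here, compound 2 has only one measured neighbour, and the two cannot be ranked: the gap is a 1.7-fold lower number from compound 1 to compound 2 (0.23 log units; within the scatter) and so no real difference can be claimed.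

Compound 3 `CC(C)=CCc1cc(C(=O)Nc2cc3ccc(OCCCNc4ccccc4)c(C)c3oc2=O)ccc1O` differs from compound 2 in one group, with phenyl in place of 2-hydroxyethyl on an amine nitrogen. The count of that swap reads phenyl in place of 2-hydroxyethyl on an amine nitrogen and everything else stays the same.

Among the compounds with values here, no measured pair tests this swap directly. Within the data shown here, the one measured step replaced a different stretch of the chain and stayed within the scatter, which gives a hint that this end of the molecule tolerates change, but it is thin evidence. No phenyl group on this nitrogen has been measured, so no direction can be argued, and no shift beyond the scatter is expected in this assay for now. The expected change is a 1.0-fold lower number from compound 2 to compound 3 (0.02 log units; within the scatter) and it remains uncertain. For compound 3 the estimated value is 1500 nM with an expected range from 500 nM to 4500 nM in this read-out.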

Compound 3, half-maximal inhibitory concentration: > 50000 nM
Compound 3 gave a limit, no number; the forecaster's own chance of this, stated with the estimate: 10%; at least 33-fold (1.52 log units) between middle value and limit.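

In this assay, the group on this amine nitrogen turns out to matter a great deal, which the earlier pair, whose values lay within the scatter of each other, gave no sign of: the swap of 2-hydroxyethyl for phenyl gives an at least 32-fold higher number from compound 2 to compound 3 (1.50 log units; beyond the scatter). The same drop appears against the compound with the 1-methylpiperidin-3-yl group, with an at least 18-fold higher number from compound 1 to compound 3 (1.27 log units; beyond the scatter), so this end of the molecule accepts some changes but not every change. Compound 3 gave a limit and not a number, so the true size of both steps stays unknown: the limit of > 50000 nM in this assay, at which 1 of the 3 values shown sits.

The swap removes a chain carrying a hydroxyl group and puts an aromatic ring straight onto the nitrogen, so the compounds shown cannot tell whether losing the hydroxyl group or gaining the ring accounts for the drop. A plain ethyl group or a 2-methoxyethyl group on this nitrogen would test the loss of the hydroxyl group, and a benzyl group would test whether the ring does better when a carbon separates it from the nitrogen.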